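Shortening the Chain on a Purine Nucleoside Analogue

This account rests on a few compounds, and the source may have more. Where it says the series, first, only, none or still open, it means among the compounds named here.

Measured compounds:
compound 1, `C=CCn1c(=O)n(C2C=CC(CO)O2)c2nc(N)nc(O)c21`: 84%
compound 2, `CCCCCCCCCCn1c(=O)n(C2OC(CO)[C@@H](O)[C@H]2O)c2nc(N)nc(O)c21`: 0%

Of the compounds shown here, two have been measured in a functional assay on the whole organism with Mus musculus as the target; a lower number here means a smaller maximal response, a higher number a larger maximal response. Compound 1 `C=CCn1c(=O)n(C2C=CC(CO)O2)c2nc(N)nc(O)c21` gives 84%. Compound 2 `CCCCCCCCCCn1c(=O)n(C2OC(CO)[C@@H](O)[C@H]2O)c2nc(N)nc(O)c21` gives 0%, the lowest of the two numbers; compound 1 stands far higher, a gap beyond the usual scatter. Within the data shown here, the two compounds differ in more than one place, so no single step between them is defined, and their values show only that a short unsaturated chain on one sugar gives a large maximal response while a decyl chain on another gives none.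

Compound 3 `CCCCn1c(=O)n(C2OC(CO)[C@@H](O)[C@H]2O)c2nc(N)nc(O)c21` is not yet measured. It differs from compound 2 in one place: hydrogen in place of hexyl on a saturated chain carbon, four bonds along the chain from an aromatic nitrogen.

Among the measured compounds shown here, with no single-change step available, the expectation rests on the contrast between the measured compounds. The step from compound 2 to compound 3 is expected to be upward and beyond the scatter, a number 40 percentage points higher from compound 2 to compound 3 (beyond the scatter), since compound 1, carrying the shortest chain seen here, gives 84% in this assay. Compound 3 is accordingly estimated at 40%, with a range from 5% to 85%.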

Compound 3, largest response reached (reported as maximal response), in percent of the reference or control that the assay uses: 70%
Beside the measured number, compound 3's estimate is 30 percentage points below it, within the range that was stated.
By their numbers in this assay, from the lowest: compound 2; then compound 3; then compound 1.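

With the sugar and the shared core unchanged, hydrogen in place of hexyl on a saturated chain carbon, four bonds along the chain from an aromatic nitrogen, gives a number 70 percentage points higher from compound 2 to compound 3 (beyond the scatter) in this assay. This single change is enough to produce a large difference in maximal response, something the earlier pair could not show, as those compounds also differ in the sugar. The data offer no explanation for the size of this step.

The compounds shown leave open whether the response falls gradually or abruptly between the chains of compound 3 and compound 2, which a hexyl or an octyl chain at this position would help to settle. Also open, from the compounds shown here alone, is how a shorter propyl chain, or a chain ending in an amine or a carboxylic acid, would behave on this sugar.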